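Propyl ether on the shared core of compound 1

The compounds below may be only part of what the source reports. "The series", "measured", "known", "first", "only" and "open" are said of these compounds alone.

Among the numbers in hand, compound 1 `CC1CCC(Oc2cccc3ccc(N)nc23)C1` stands lowest of the two: in an assay on cells with melanin-concentrating hormone receptor 1 (Homo sapiens) as the target, read by radioligand binding (on this read-out lower numbers stand for stronger inhibition and higher numbers for weaker inhibition), compound 1 gives 823 nM. Compound 2 `CCOCC(C)Oc1cccc2ccc(N)nc12` gives 1070 nM, and the step is a 1.3-fold higher number from compound 1 to compound 2 (0.11 log units; within the scatter). Compound 3 `CC#CCCOc1cccc2ccc(N)nc12` reaches only a limit of the assay, > 2000 nM; this is the limit of > 2000 nM in this assay, at which 1 of the 3 values shown sits. The step of an at least 2.4-fold higher number from compound 1 to compound 3 (0.38 log units; beyond the scatter) is the only one so far beyond the scatter, while an at least 1.8-fold higher number from compound 2 to compound 3 (0.27 log units; that floor lies within the scatter).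

Compound 4 `CCCOc1cccc2ccc(N)nc12` is not yet measured. It differs from compound 1 by propyl in place of 3-methylcyclopentyl on an oxygen on an aromatic ring. Both steps that start from compound 1 and trade the ring for a chain bear on it: the one to an ether-containing chain stayed within the scatter, the one to pent-3-yn-1-yl weakened binding at least modestly. A weakening step in this assay of modest size is therefore expected. The expected step is a 2.4-fold higher number from compound 1 to compound 4 (0.39 log units; beyond the scatter). Compound 4 is estimated at 2000 nM, with a range from 900 nM to 5000 nM.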

Compound 4, half-maximal inhibitory concentration: 1100 nM
Compound 4: middle estimate off by 1.8-fold (0.26 log units), on the high side; low and high end bracket the measured number.
By their numbers in this assay, from the lowest: compounds 1, 2 and 4 (each within the scatter of the next). At a limit, above all of these: compound 3.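

In this assay, the step of a 1.3-fold higher number from compound 1 to compound 4 (0.13 log units; within the scatter) shows that on this oxygen on an aromatic ring, the 3-methylcyclopentyl ring can give way to the much smaller propyl with no change beyond the scatter. The step of a 1.0-fold higher number from compound 2 to compound 4 (0.01 log units; within the scatter) likewise separates propyl from the larger oxygen-containing chain of compound 2 by no readable margin, so among compounds 1, 2 and 4, neither a ring nor the count of heavy atoms goes with a difference in this assay. The step of an at least 1.8-fold lower number from compound 3 to compound 4 (0.25 log units; that floor lies within the scatter) cannot be read as a size, since compound 3 stands at a limit and not at a number: the limit of > 2000 nM in this assay, at which 1 of the 4 values shown sits.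

Going by these compounds, whether any group on this oxygen can take the number beyond the scatter of these three compounds remains open. A butyl chain, an aminoethyl chain or a carboxylic acid-bearing chain would test this.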